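This account rests on a few compounds, and the source may have more. Where it says the series, first, only, none or still open, it means among the compounds named here.

Measured compounds in a functional assay on HCT-116 cells (Homo sapiens) for inhibition, read by MTT assay, with a stated time of 48 h; on this read-out higher numbers stand for weaker inhibition and lower numbers for stronger inhibition:

compound 1 `CCC/C=C/C(=O)N(Cc1ccc(OC)c(O)c1)c1cc(OC)c(OC)c(OC)c1`: 95 nM
compound 2 `C/C=C/C(=O)N(Cc1cc(OC)c(OC)c(OC)c1)c1ccc(OC)c(O)c1`: 8450 nM
compound 3 `COc1ccc(CNc2cc(OC)c(OC)c(OC)c2)cc1C`: 60900 nM

Compound 1 gives the lowest number of the three in this assay. Compound 2 sits well above it, beyond the usual scatter, and compound 3, which carries no acyl group on the nitrogen at all, gives the highest number of the set, also beyond the scatter from compound 1. Among the compounds with values here, no two of the measured compounds differ in only one place, so no single step between them can be read off; the values simply show that compound 1 stands apart from compound 2 and compound 3.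

Compound 4 `COc1ccc(CN(C(C)=O)c2cc(OC)c(OC)c(OC)c2)cc1O` has not yet been measured. It differs from compound 1 in one place: methyl in place of pent-1-en-1-yl on a carbonyl carbon. The amide itself is kept; only the group on its carbonyl carbon changes.

Within the data shown here, no measured pair tells the size of this particular change. Compound 3, with the acyl group removed entirely, is the weakest of the three, and compound 2, with a shorter alkenyl chain, is also far weaker than compound 1, which suggests the chain matters. The step of a 16-fold higher number from compound 1 to compound 4 (1.20 log units; beyond the scatter) is therefore expected to be a loss of potency beyond the scatter. Compound 4 is estimated at 1500 nM, with a range of 300 nM to 8000 nM.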

Compound 4, half-maximal inhibitory concentration: 270 nM
The estimate for compound 4 lay 5.6-fold (0.74 log units) above the measured number, outside the stated range (below it).
By their numbers in this assay, from the lowest: compound 1; then compound 4; then compound 2; then compound 3.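

In this assay, the exchange of pent-1-en-1-yl for methyl on the carbonyl carbon gives a 2.8-fold higher number from compound 1 to compound 4 (0.45 log units; beyond the scatter), a modest step that is nonetheless beyond the scatter, so the full alkenyl chain is not needed for compound 4 to reach 270 nM. Within the data shown here, this is the only single-place step, so it is the first direct reading at this position; no other step can be read, and the much higher numbers of compound 2 and compound 3 cannot be assigned to the acyl chain alone. No measurement in hand accounts for the size of this step.

The two ends of the change, methyl and pent-1-en-1-yl, leave open how intermediate or saturated groups on the same carbonyl carbon, such as ethyl, propyl or pentyl, would read in this assay, and so whether the step follows chain length or the double bond. Also open, on these data alone, is how a longer chain, a phenyl ring or a carboxylic acid at this place would compare with compound 1 and compound 4.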